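The source may hold more compounds than are shown below. What is called first, only, known or untested is meant among the compounds shown, and "the series" means these compounds.

Compound 3 `Cc1ccc(S(=O)(=O)NCc2ccc(CNC(=O)c3ccc(F)cc3)cc2)cc1` stands lowest of the numbers shown in an assay on MDA-MB-231 cells for binding affinity to C-X-C chemokine receptor type 4 (Homo sapiens), read by immunofluorescence and microscopy, with stated times of 10 min and 30 min (on this read-out higher numbers stand for an effect only at larger amounts of compound and lower numbers for an effect already at smaller amounts), where compound 3 gives 1 nM. Its nearest neighbour is compound 2 `Cc1ccc(S(=O)(=O)NCc2ccc(CNC(=O)c3ccc([N+](=O)[O-])cc3)cc2)cc1`, which in this assay gives 10 nM; the step of a 10-fold lower number from compound 2 to compound 3 (1.00 log units; beyond the scatter) is beyond the scatter. Compound 1 `Cc1ccc(S(=O)(=O)NCc2ccc(CNC(=O)c3ccccc3)cc2)cc1` returns only a limit in this assay, > 1000 nM. From that limit, the steps of an at least 100-fold lower number from compound 1 to compound 2 (2.00 log units; beyond the scatter) and an at least 1000-fold lower number from compound 1 to compound 3 (3.00 log units; beyond the scatter) are both large, so placing either nitro or fluoro on the aromatic carbon brings a far lower number than hydrogen.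

Compound 4 `COc1cccc(C(=O)NCc2ccc(CNS(=O)(=O)c3ccc(C)cc3)cc2)c1` differs from compound 3 by 3-methoxyphenyl in place of 4-fluorophenyl on a carbonyl carbon. For the measured compounds named here, no measured step exchanges fluoro for methoxy, so the evidence is indirect: a group on the ring helps greatly in an at least 1000-fold lower number from compound 1 to compound 3 (3.00 log units; beyond the scatter), while swapping one group for another shifts the number only modestly in a 10-fold lower number from compound 2 to compound 3 (1.00 log units; beyond the scatter). Compound 4 is therefore expected to stay well below the limit but to move toward a higher number, a step estimated as a 10-fold higher number from compound 3 to compound 4 (1.00 log units; beyond the scatter). The estimate for compound 4 in this assay is 10 nM, with a range from 1 nM to 100 nM.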

Compound 4, effective concentration (reported as EC, without a stated level of effect): 10 nM
The estimate for compound 4 equals the measured number at the digits printed; low and high end bracket the measured number.
By their numbers in this assay, from the lowest: compound 3; then compounds 2 and 4 (each within the scatter of the next). At a limit, above all of these: compound 1.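

In this assay, a third group on the ring attached to the carbonyl carbon improves on plain hydrogen, as an at least 100-fold lower number from compound 1 to compound 4 (2.00 log units; beyond the scatter) shows, so this gain is not confined to nitro and fluoro or to groups named at the 4-position. The groups are still not interchangeable: a 10-fold higher number from compound 3 to compound 4 (1.00 log units; beyond the scatter) sets 3-methoxyphenyl apart from 4-fluorophenyl, while no change at the digits printed from compound 2 to compound 4 (within the scatter) leaves it indistinguishable from 4-nitrophenyl. The step from hydrogen starts from a limit held by compound 1, so its full size cannot be read: the limit of > 1000 nM in this assay, at which 1 of the 4 values shown sits.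

Compound 4 changes both the group and its place on the ring, so the compounds shown cannot separate these two changes. Also open, on these data alone, are how 4-methoxyphenyl would compare, and what an amine or a carboxylic acid on this ring would give.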